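Fluorobenzothiazole Replaces Methylbenzimidazole on the Ribose Core

This account rests on a few compounds, and the source may have more. Where it says the series, first, only, none or still open, it means among the compounds named here.

Three triphosphate nucleotide analogues have been measured in a functional assay for agonist activity at P2Y purinoceptor 2 (Homo sapiens), read by FLIPR; a lower number here means that less compound is needed, a higher number that more compound is needed for the effect. Compound 2 `Cn1c([C@@H]2O[C@H](COP(=O)(O)OP(=O)(O)OP(=O)(O)O)[C@@H](O)[C@H]2O)nc2ccccc21` gives 200 nM, the lowest of the three numbers. Compound 3 `Cc1ccc2oc([C@@H]3O[C@H](COP(=O)(O)OP(=O)(O)OP(=O)(O)O)[C@@H](O)[C@H]3O)nc2c1` gives 390 nM, and compound 1 `COc1cccc2sc([C@@H]3O[C@H](COP(=O)(O)OP(=O)(O)OP(=O)(O)O)[C@@H](O)[C@H]3O)nc12` gives 700 nM. Among the measured compounds shown here, the one single-point step among them, a 2.0-fold higher number from compound 2 to compound 3 (0.29 log units; within the scatter), exchanges one bicyclic aromatic group for another and stays within the scatter. Compound 1 and compound 2 differ in more than one place, so their values can only be set side by side: compound 1 stands well higher than compound 2.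

The unmeasured compound 4 `O=P(O)(O)OP(=O)(O)OP(=O)(O)OC[C@H]1O[C@@H](c2nc3cc(F)ccc3s2)[C@H](O)[C@@H]1O` is obtained from compound 2 by the change (5-fluoro-1,3-benzothiazol-2-yl in place of 1-methyl-1H-benzimidazol-2-yl on a saturated ring carbon). For the measured compounds named here, the step from compound 2 to compound 3 is the only measured change of the same kind, and it was small. Compound 1 carries the same bicyclic ring system as compound 4, with a methoxy group in place of the fluorine, and sits higher than compound 2. Compound 4 is therefore expected to give 450 nM in this assay, between 180 nM and 1200 nM, a step of a 2.3-fold higher number from compound 2 to compound 4 (0.35 log units; beyond the scatter) that is estimated to lie at or just beyond the edge of the scatter, in the direction of a higher number.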

Compound 4, half-maximal effective concentration: 3 nM
Beside the measured number, compound 4's estimate is 150-fold (2.18 log units) above it; the whole stated range lies above it.
By their numbers in this assay, from the lowest: compound 4; then compounds 2, 3 and 1 (each within the scatter of the next, the first and the last beyond it).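

In this assay, the group on the saturated ring carbon next to the ring oxygen proves far from indifferent, with a 67-fold lower number from compound 2 to compound 4 (1.82 log units; beyond the scatter) and a 130-fold lower number from compound 3 to compound 4 (2.11 log units; beyond the scatter) when 5-fluoro-1,3-benzothiazol-2-yl enters. Among the compounds shown here, the one earlier step at this place, a 2.0-fold higher number from compound 2 to compound 3 (0.29 log units; within the scatter), had suggested that one bicyclic aromatic group could stand in for another with little consequence, but the new steps show that such an exchange can greatly reduce the amount of compound needed, even though the groups that leave and enter have matching counts of heavy atoms, rings, hydrogen-bond donors and hydrogen-bond acceptors. Nothing given here offers an explanation for the size of these steps.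

The fluorine and the ring system change together in both steps, so the compounds shown cannot separate what each contributes, and the plain 1,3-benzothiazol-2-yl group would be needed to tell them apart. They also leave open whether the gain would survive a chlorine, a nitrile or an amine in place of the fluorine, or a move of the fluorine to another ring carbon.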